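A few compounds are considered here, and "the series" means these few. Any claim that something is new, unique, unknown or untested is made for them only; others in the source may bear on it.

Working notes on the series in an ADME assay on HepG2 cells (Homo sapiens) for cytotoxicity, read by luminescence, with a stated time of 72 h; on this read-out lower numbers stand for an effect already at smaller amounts and higher numbers for an effect only at larger amounts of compound.

Compound 1 `CCOC(=O)c1c(-c2cccc(-c3ccccc3)c2)[nH]c2cc(OC)ccc2c1=O` carries a phenyl on the aromatic carbon in question. In this assay compound 1 gives only a limit, > 21500 nM. Compound 2 `CCCCOc1cccc(-c2[nH]c3cc(OC)ccc3c(=O)c2C(=O)OCC)c1` has butoxy in place of phenyl on that aromatic carbon. In this assay compound 2 likewise reaches only a limit, > 21500 nM. Compound 3 `CCOC(=O)c1c(-c2cccc([N+](=O)[O-])c2)[nH]c2cc(OC)ccc2c1=O` has nitro in the same place. In this assay compound 3 also stops at a limit, > 21500 nM. The three steps among them, a step that the two limits leave unreadable from compound 1 to compound 2, a step that the two limits leave unreadable from compound 1 to compound 3 and a step that the two limits leave unreadable from compound 2 to compound 3, are therefore unreadable in size and direction; all three values sit at the limit of > 21500 nM in this assay, at which 3 of the 3 values shown sit.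

Compound 4 `CCOC(=O)c1c(-c2cccc(O)c2)[nH]c2cc(OC)ccc2c1=O` is not yet measured in this assay. It differs from compound 2 as follows: hydrogen in place of butyl on an oxygen on an aromatic ring. Among the compounds with values here, no measured step shows an effect within the reading range, so none bears on this change with a readable size. The expectation is therefore that compound 4 behaves like compounds 1, 2 and 3, with a step from compound 2 of a step that the limit leaves unreadable from compound 2 to compound 4, most likely again as a limit. For compound 4 the estimate in this assay is 30000 nM, with a range from 15000 nM to 100000 nM.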

Compound 4, half-maximal effective concentration: > 21500 nM
Compound 4 was reported as a limit; the forecaster's own chance of this, stated with the estimate: 80%; the middle value is on the limit's open side.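

Compound 4 also ends at a limit, so none of its steps from compounds 1, 2 and 3 can be read in size or direction: the limit of > 21500 nM in this assay, at which 4 of the 4 values shown sit. The compounds shown leave open which change, if any, would bring a value in this assay inside the reading range.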